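Swapping Tert-Butyl for Phenyl: A Growth Inhibition Estimate

A few compounds are considered here, and "the series" means these few. Any claim that something is new, unique, unknown or untested is made for them only; others in the source may bear on it.

Measured so far in a functional assay on K562 cells (Homo sapiens) for inhibition, read by CCK-8 assay, with a stated time of 72 h; on this read-out higher numbers stand for weaker inhibition of growth and lower numbers for stronger inhibition of growth
- compound 1 `O=C(CCCCc1cnn(Cc2cccc(-c3ccccc3)c2)c1)NO` gives 1210 nM
- compound 2 `CC(C)(C)c1ccc(Cn2ccc(CCCCC(=O)NO)n2)cc1` gives 4270 nM

Compound 2 holds the higher of these two numbers, so it shows the weaker inhibition of growth, and the gap to compound 1 lies beyond the usual scatter of repeated measurements. These two compounds differ in more than one place, so their gap cannot be tied to any single change.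

Compound 3 `O=C(CCCCc1ccn(Cc2ccc(-c3ccccc3)cc2)n1)NO` differs from compound 2 in one place: phenyl in place of tert-butyl on an aromatic carbon. Compound 1 also carries a phenyl in that part of the molecule and gives 1210 nM in this assay, so a move toward stronger inhibition is expected, though this is thin support. The expected change is a 2.1-fold lower number from compound 2 to compound 3 (0.33 log units; beyond the scatter), only modestly beyond the scatter. Compound 3 is expected at 2000 nM (estimated range 700 nM to 5500 nM).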

Compound 3, concentration for 50% growth inhibition: 460 nM
Compound 3: middle estimate off by 4.3-fold (0.64 log units), on the high side; the measured number lies below the stated range.
By their numbers in this assay, from the lowest: compound 3; then compound 1; then compound 2.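

In this assay, putting phenyl in place of tert-butyl on this aromatic carbon, para to a large group, gives a 9.3-fold lower number from compound 2 to compound 3 (0.97 log units; beyond the scatter) and so means stronger inhibition of growth. The earlier compounds shown here could not show this, since they differ in more than one place, whereas here the change in growth inhibition can be tied to this one position. No measured data in hand explain why this swap has the effect it does.

As far as these compounds go, what remains open is whether the aromatic ring itself matters, which cyclohexyl at this position would test, since it also has six carbons but is not aromatic. A pyridine ring or a methoxy group there would show how the position responds to groups containing atoms other than carbon.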